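The source may report more compounds than this note shows. Statements on the series, on what has been measured and on what is new or still open speak of the compounds shown alone.

Measured compounds:
compound 1, `CC1=C(C(=O)Nc2ccc(F)c(Cl)c2)C(c2cccc(O)c2)NC(=S)N1`, with 50100 nM
compound 2, `CC1=C(C(=O)Nc2ccc(Cl)c(Cl)c2)C(c2cccc(Oc3ccccc3)c2)NC(=S)N1`, with 8510 nM

Both were tested in a functional assay on CAKI-1 cells (Homo sapiens) for cytotoxicity, read by sulforhodamine B assay, with a stated time of 48 h; a lower number here means a stronger inhibitor of growth, a higher number a weaker inhibitor of growth. In this assay compound 1 gives 50100 nM, the higher of the two numbers, and compound 2 gives 8510 nM, a gap that lies beyond the usual scatter of such measurements. Compound 2 differs from compound 1 in more than one place, so its number says nothing about any single change on its own.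

Compound 3, `COc1cccc(C2NC(=S)NC(C)=C2C(=O)Nc2ccc(F)c(Cl)c2)c1`, has not yet been measured. It differs from compound 1 in just one place: methyl in place of hydrogen on an oxygen on an aromatic ring. Within the data shown here, no pair of measured compounds shows this particular change by itself, so there is no measured step to lean on, only the general observation that a change of one methyl group is a small one.

For this reason the step is expected to be modest, a 1.7-fold lower number from compound 1 to compound 3 (0.22 log units; within the scatter), possibly within the scatter, leaning if anything toward a lower number. Compound 3 is therefore estimated at 30000 nM, with a likely range from 10000 nM to 90000 nM.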

Compound 3, concentration for 50% growth inhibition: 49000 nM
Compound 3: the middle estimate sits 1.6-fold (0.21 log units) below what was measured; measured number inside the range.
By their numbers in this assay, from the lowest: compound 2; then compounds 3 and 1 (each within the scatter of the next).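

In this assay, among these compounds, the exchange of 3-hydroxyphenyl for 3-methoxyphenyl gives a 1.0-fold lower number from compound 1 to compound 3 (0.01 log units; within the scatter) and is the first direct reading of a single change at this position. Within this pair, the hydrogen on the oxygen can therefore be replaced by a methyl group without a difference that can be told from the scatter, so this one change gives no sign that the free hydroxy group matters for growth inhibition in these cells. No measurement shown here explains this result.

Going by these compounds, the pair covers only hydrogen and methyl on this oxygen, so it remains open whether a longer chain such as ethyl or propyl, or a chain ending in an amine or a carboxylic acid, would also leave the number in the same place. It is also unknown whether an amine or a fluorine directly on the aromatic ring, in place of the whole hydroxy or methoxy group, would give a number distinct from those of compound 1 and compound 3.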